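This account rests on a few compounds, and the source may have more. Where it says the series, first, only, none or still open, it means among the compounds named here.

Measured so far: compound 1 `O=C(O)CC/C=C\C[C@H]1[C@H](F)CC[C@@H]1NS(=O)(=O)c1ccc(Cl)c(Cl)c1` gives 1700 nM in a functional assay on a cell-free system (plasma) for inhibition of thromboxane A2 receptor (Homo sapiens), read by turbidimetry; on this read-out higher numbers stand for weaker inhibition and lower numbers for stronger inhibition; compound 2 `O=C(O)CCC/C=C\C[C@H]1[C@H](F)CC[C@@H]1NS(=O)(=O)c1ccc(Cl)c(Cl)c1` gives 630 nM in this assay.

Compound 1 stands highest of the two numbers; its nearest neighbour is compound 2, reached by a 2.7-fold lower number from compound 1 to compound 2 (0.43 log units; beyond the scatter). Compound 3 `O=C(O)CC/C=C\C[C@H]1[C@H](F)CC[C@@H]1NS(=O)(=O)c1ccccc1` differs from compound 1 by phenyl in place of 3,4-dichlorophenyl on a sulfonyl sulfur. Among the measured compounds shown here, no measured step touches the aryl group on the sulfonyl sulfur; the only measured step, a 2.7-fold lower number from compound 1 to compound 2 (0.43 log units; beyond the scatter), concerns the chain and gives no guide here. A weaker inhibition is expected, of modest to large size. Compound 3 is estimated at 8000 nM, range 2500 nM to 25000 nM, which is an expected 4.7-fold higher number from compound 1 to compound 3 (0.67 log units; beyond the scatter).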

Compound 3, half-maximal inhibitory concentration: 2000 nM
Beside the measured number, compound 3's estimate is 4.0-fold (0.60 log units) above it, and the stated range ends above it.
By their numbers in this assay, from the lowest: compound 2; then compounds 1 and 3 (each within the scatter of the next).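

Among the compounds shown here, this is the first measured step at the aryl group on the sulfonyl sulfur: in this assay, phenyl in place of 3,4-dichlorophenyl gives a 1.2-fold higher number from compound 1 to compound 3 (0.07 log units; within the scatter) and stays within the scatter. For the compounds shown here, the two chlorine atoms are therefore not needed to hold the number at this chain length, whereas the chain step a 2.7-fold lower number from compound 1 to compound 2 (0.43 log units; beyond the scatter) remains the only change beyond the scatter. No evidence bears on why this position tolerates the change.

Still open, going by these compounds, is whether a methoxy or nitro group on the phenyl would move the number. Also open, on these data alone, is whether phenyl behaves the same way on the longer chain of compound 2.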